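A few compounds are considered here, and "the series" means these few. Any claim that something is new, unique, unknown or untested is made for them only; others in the source may bear on it.

Compound 2 `CCN1CCN(CCCCOc2ccccc2/C=C/c2ccccc2)CC1` and compound 1 `C(=C/c1ccccc1OCCCCN1CCCCC1)\c1ccccc1` share a core and differ only at the ring attached to the chain. In a functional assay on the whole organism with Mus musculus as the target, in the maximal electroshock model, at a dose of 50 mg/kg by the oral route (a lower number here means less inhibition, a higher number more inhibition at the dose given (going by the name of the read-out)), compound 1 gives 42.9%, and in the same test compound 2 gives 33.3%. The step of a number 9.6 percentage points lower from compound 1 to compound 2 (within the scatter) lies within the scatter, so the two numbers cannot be told apart; compound 2 simply stands at the lower of two values that agree with each other. Compound 3 `CCCN1CCN(CCCCOc2ccccc2/C=C/c2ccccc2)CC1` is the next step from compound 2, carrying (methyl in place of hydrogen on a saturated chain carbon, two bonds along the chain from an amine nitrogen in a ring). Within the data shown here, no measured step bears directly on this change; the only known step, from one ring to another, is within the scatter and offers no direction. The expected change a number 1.7 percentage points higher from compound 2 to compound 3 (within the scatter) is therefore none beyond the scatter. Compound 3 is estimated at 35% in this assay, within a range of 15% to 55%.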

Compound 3, a percentage reported as inhibition, in the whole organism at one dose (the size of the read-out at that dose, not a potency): 42.9%
Beside the measured number, compound 3's estimate is 7.9 percentage points below it; measured number inside the range.
By their numbers in this assay, from the lowest: compounds 2, 1 and 3 (each within the scatter of the next).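

Going from ethyl to propyl in the 4-ethylpiperazin-1-yl group, a methyl in place of hydrogen on a saturated chain carbon, two bonds along the chain from an amine nitrogen in a ring, gives in this assay a number 9.6 percentage points higher from compound 2 to compound 3 (within the scatter). So this small extension has no effect that can be told from the scatter, and the swap of piperidin-1-yl for 4-propylpiperazin-1-yl, which gives no change at the digits printed from compound 1 to compound 3 (within the scatter), likewise shows no readable effect. No evidence is available that would account for these readings.

From the compounds shown here alone, whether a larger group in this place, such as 4-butylpiperazin-1-yl or 4-benzylpiperazin-1-yl, or a morpholin-4-yl ring on the chain, would move the number beyond the scatter remains open. Going by these compounds, with a reading at one dose only, how these compounds compare in potency also remains open.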